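This account rests on a few compounds, and the source may have more. Where it says the series, first, only, none or still open, it means among the compounds named here.

Three compounds share one core and differ in the chain and the group hanging from it. Compound 1 `C/N=C(/NC#N)NCCCCCCn1nc(-c2ccccc2)ccc1=O` carries the longest chain. In a functional assay on the whole organism (stomach) with Rattus norvegicus as the target (a lower number here means that less compound is needed, a higher number that more compound is needed for the effect), compound 1 gives only a limit, > 100 mg/kg. Compound 2 `C/N=C(\NC#N)NCCCCn1nc(-c2ccccc2)ccc1=O` gives 32.4 mg/kg in this assay. Compound 3 `CC/N=C(\S)NCCCn1nc(-c2ccccc2)ccc1=O` again gives only a limit in this assay, > 100 mg/kg. Compound 3 therefore stands at the edge of what the assay can report, together with compound 1, because of the limit of > 100 mg/kg in this assay, at which 2 of the 3 values shown sit. Going by the values given here, the one measured step, an at least 3.0-fold higher number from compound 2 to compound 3 (0.48 log units; beyond the scatter), swaps the group itself and shortens the chain at the same time, so it cannot be pulled apart into a chain effect and a group effect.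

Compound 4 `CC/N=C(\S)NCCCCCn1nc(-c2ccccc2)ccc1=O` keeps the group of compound 3 and lengthens the chain: a group of 8 heavy atoms (5 carbon, 2 nitrogen, 1 sulfur; no ring) in place of a group of 6 heavy atoms (3 carbon, 2 nitrogen, 1 sulfur; no ring), on a saturated chain carbon, three bonds along the chain from an aromatic nitrogen. Among the compounds with values here, no measured step changes chain length alone within this group, so the direction of this step is not settled by the data; compound 1 and compound 2 differ in chain length and show a limit against a number, but they also differ elsewhere. Starting from a limit, compound 4 is expected to remain near it, so the expected step that the limit leaves unreadable from compound 3 to compound 4 is small. Compound 4 is estimated at 150 mg/kg, within 40 mg/kg to 600 mg/kg.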

Compound 4, dose for half-maximal effect: 51.8 mg/kg
Beside the measured number, compound 4's estimate is 2.9-fold (0.46 log units) above it; the range from low to high includes it.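

Going by these compounds alone, compound 4 gives the first real number in this assay for a compound whose end group holds sulfur, so a group of this kind does not have to sit at the edge of what the assay can report. Two steps start from a limit, an at least 1.9-fold lower number from compound 3 to compound 4 (0.28 log units; that floor lies within the scatter) and an at least 1.9-fold lower number from compound 1 to compound 4 (0.28 log units; that floor lies within the scatter), and each shows only a floor that lies within the scatter, so neither proves a real gain, because the starting point of each is not a true number: the limit of > 100 mg/kg in this assay, at which 2 of the 4 values shown sit. Compound 2 and compound 4 cannot be told apart, with a 1.6-fold higher number from compound 2 to compound 4 (0.20 log units; within the scatter), so in this small set the group with the nitrile and the group with sulfur each reach a measurable number on a suitable chain.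

Going by these compounds, whether a still longer chain on the sulfur-bearing group keeps a measurable number stays open, as does what a simple amine or a carboxylic acid at the end of the chain would give in this assay. On these data alone, the true values of compound 1 and compound 3 also remain unknown, and with them the real size of the steps that start from these two compounds.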